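A Chlorine Moved: From Compound 2 to Compound 4

The compounds below may be only part of what the source reports. "The series", "measured", "known", "first", "only" and "open" are said of these compounds alone.

Compound 1 `CC1(c2ccccc2)CC(=O)N(CC(=O)N2CCN(c3ccc(Cl)cc3)CC2)C1=O`: "not active" (no number reported)
Compound 2 `CC1(c2ccccc2)CC(=O)N(CC(=O)N2CCN(c3cccc(Cl)c3)CC2)C1=O`: 300 mg/kg
Compound 3 `CC1(c2ccccc2)CC(=O)N(CC(=O)N2CCC(Cc3ccccc3)CC2)C1=O`: "not active" (no number reported)

Of the compounds shown here, three have been tested in a functional assay on the whole organism (strain CD-1) with Mus musculus as the target, in the maximal electroshock model, with a stated time of 0.5 h; a higher number here means that more compound is needed for the effect, a lower number that less compound is needed. Compound 1 is reported as "not active" (no number reported) and compound 3 as "not active" (no number reported), with no number for either. Compound 2 is the only one with a stated minimum effective dose, giving 300 mg/kg in this assay. Compound 4 `CC1(c2ccccc2)CC(=O)N(CC(=O)N2CCN(c3ccccc3Cl)CC2)C1=O` differs from compound 2 in one place: 2-chlorophenyl in place of 3-chlorophenyl on an amine nitrogen in a ring. For the measured compounds named here, no measured pair shows the effect of moving the chlorine, so the direction of the step is open. A step no larger than the scatter is expected, no change at the digits printed from compound 2 to compound 4 (within the scatter), with a real chance that only an inactive result is reported. For compound 4 the estimated value in this assay is 300 mg/kg, within 100 mg/kg to 600 mg/kg.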

Compound 4, minimum effective dose: "not active" (no number reported)
Compound 4: no number reported; there is nothing to compare the estimate with.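

For the compounds shown here, compound 4 carries no number, and no step from compound 2 to compound 4 can be read. No measured evidence bears on this result. The compounds shown leave open whether the place of the chlorine governs the minimum effective dose.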